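Swapping amino for fluoro on a chalcone scaffold

The compounds below may be only part of what the source reports. "The series", "measured", "known", "first", "only" and "open" are said of these compounds alone.

Compound 1, `O=C(/C=C/c1ccc(N2CCCC2)cc1)c1ccc([N+](=O)[O-])cc1`: 21300 nM
Compound 2, `COc1cc(O)ccc1/C=C/C(=O)c1ccc(N)cc1`: "not determined" (no result reported)
Compound 3, `O=C(/C=C/c1ccc(F)cc1)c1ccc(O)cc1`: 13800 nM

All three share a common core in which two aromatic rings are joined through a carbonyl and a double bond. In a functional assay on T47D cells (Homo sapiens) for cytotoxicity, read by MTT assay (a lower number here means a stronger inhibitor, a higher number a weaker inhibitor), compound 1 gives 21300 nM, and compound 3 gives 13800 nM. For compound 2 the outcome in this assay is "not determined" (no result reported), so there is no number on which compound 2 can be placed within this group.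

Compound 4, `COc1cc(O)ccc1/C=C/C(=O)c1ccc(F)cc1`, has not yet been tested. It differs from compound 2 in one place: fluoro in place of amino on an aromatic carbon. Since compound 2 has no value, the size of this step in this assay cannot be taken from the data. Without a measured starting point, the expectation is simply that compound 4 will fall within the broad band shown by compound 1 and compound 3, and no step beyond the usual scatter can be foreseen in either direction.

Compound 4 is therefore expected to give about 15000 nM in this assay, with a plausible range from 4000 nM to 60000 nM, the guide being that compound 3 gives 13800 nM with the same fluoro group at the corresponding position.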

Compound 4, half-maximal inhibitory concentration: 8510 nM
Compound 4: the middle estimate sits 1.8-fold (0.25 log units) above what was measured; low and high end bracket the measured number.
By their numbers in this assay, from the lowest: compounds 4, 3 and 1 (each within the scatter of the next, the first and the last beyond it).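

For the compounds shown here, compound 2 has no number in this assay, and compound 4 differs from compound 1 and compound 3 in more than one place, so no step to compound 4 can be read. The compounds shown leave open how far fluoro in place of amino shifts the result in this assay. No measured property here bears on the result of compound 4.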